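Swapping an Aromatic Ring for a Morpholine Amide

A few compounds are considered here, and "the series" means these few. Any claim that something is new, unique, unknown or untested is made for them only; others in the source may bear on it.

Within the data shown here, compound 2 `O=C(CCCCCCc1ccccc1)c1ncc(-c2cncnc2)o1` is the only compound here with a full number. In an assay (Rattus norvegicus) for inhibition of Fatty-acid amide hydrolase 1 (Homo sapiens) (on this read-out lower numbers stand for stronger inhibition and higher numbers for weaker inhibition), compound 2 gives 22 nM. Compound 1 `O=C(CCCCCCc1ccccc1)c1ncc(-c2ncccc2C(=O)O)o1` differs from it in one place, and in this assay compound 1 gives > 50 nM, which is a limit of the assay rather than a number. The step of an at least 2.2-fold lower number from compound 1 to compound 2 (0.35 log units; beyond the scatter) is accordingly known only as a lower bound, resting on (the limit of > 50 nM in this assay, at which 1 of the 2 values shown sits), so compound 2 stands as the stronger of the two shown.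

Compound 3 `O=C(CCCCCCc1ccccc1)c1ncc(C(=O)N2CCOCC2)o1` has not yet been measured. It differs from compound 2 by (morpholin-4-yl)carbonyl in place of pyrimidin-5-yl on an aromatic carbon. Among the measured compounds shown here, no measured step covers an exchange of this kind: the single step from compound 1 to compound 2 concerns trading one six-membered aromatic ring for another, not trading a ring for an amide. The expectation for compound 3 therefore rests on little, and a weakening somewhat beyond the scatter is taken as the cautious guess. Compound 3 is estimated at 120 nM, with a range from 25 nM to 600 nM, which amounts to an expected step of a 5.5-fold higher number from compound 2 to compound 3 (0.74 log units; beyond the scatter).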

Compound 3, inhibition constant: 24 nM
Compound 3: middle estimate off by 5.0-fold (0.70 log units), on the high side; the whole stated range lies above it.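

In this assay, the aromatic carbon next to the ring oxygen takes (morpholin-4-yl)carbonyl in place of pyrimidin-5-yl with a 1.1-fold higher number from compound 2 to compound 3 (0.04 log units; within the scatter), so compound 2 and compound 3 cannot be told apart and an aromatic ring on this carbon is not needed to keep the read-out at this level. The earlier step exchanged one six-membered aromatic ring for another, whereas this one brings in a non-aromatic ring joined through a carbonyl, with the same counts of hydrogen-bond donors and acceptors as the group it replaces. Compared with the acid-bearing compound, the new group gives an at least 2.0-fold lower number from compound 1 to compound 3 (0.31 log units; beyond the scatter), and this size is only a lower bound, as the value of compound 1 is a limit: the limit of > 50 nM in this assay, at which 1 of the 3 values shown sits.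

The compounds shown do not say whether the ring oxygen of the morpholine matters, which a piperidine amide would test, or whether any ring is needed in the amide at all, which an open dimethylamide would test. They also leave open how a simple amine on this same carbon would read, and why two such different groups give values within the scatter of each other.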